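This account rests on a few compounds, and the source may have more. Where it says the series, first, only, none or still open, it means among the compounds named here.

Compound 1 `O=C(CSc1nc(Nc2ccccc2)c2ccccc2n1)Nc1ccccc1F` gives 9350 nM in a functional assay on NCI-H1975 cells (Homo sapiens) for inhibition, read by MTT assay, with a stated time of 72 h; on this read-out lower numbers stand for stronger inhibition and higher numbers for weaker inhibition.
Compound 2 `O=C(CSc1nc(Nc2ccccc2)c2ccccc2n1)Nc1cccc(F)c1` gives 6790 nM in this assay.
Compound 3 `O=C(CSc1nc(Nc2ccccc2)c2ccccc2n1)Nc1ccc(Cl)cc1Cl` gives 8410 nM in this assay.

All three compounds share one core and differ only in the ring that sits on the amide-type nitrogen. On the numbers as they stand, compound 2 shows the smallest figure, but the three cannot really be told apart: a 1.4-fold lower number from compound 1 to compound 2 (0.14 log units; within the scatter), a 1.2-fold higher number from compound 2 to compound 3 (0.09 log units; within the scatter) and a 1.1-fold lower number from compound 1 to compound 3 (0.05 log units; within the scatter). Nothing here separates one ring from another.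

Compound 4 `O=C(CSc1nc(Nc2ccccc2)c2ccccc2n1)Nc1ccc(Cl)c(Cl)c1` has not yet been measured in this assay. Its difference from compound 2 is 3,4-dichlorophenyl in place of 3-fluorophenyl on an amide-type nitrogen. The measured steps closest to this change are the two that replace a fluorophenyl with a dichlorophenyl, a 1.1-fold lower number from compound 1 to compound 3 (0.05 log units; within the scatter) and a 1.2-fold higher number from compound 2 to compound 3 (0.09 log units; within the scatter), and both stay within the scatter. Among the compounds with values here, no measured compound carries the 3,4-dichlorophenyl ring itself, so the exact new ring is untested. On this evidence the expected step is a 1.2-fold higher number from compound 2 to compound 4 (0.07 log units; within the scatter), that is, no change beyond the scatter. Compound 4 is therefore estimated at 8000 nM, with a likely range from 4000 nM to 16000 nM.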

Compound 4, half-maximal inhibitory concentration: 10400 nM
Beside the measured number, compound 4's estimate is 1.3-fold (0.11 log units) below it; low and high end bracket the measured number.
By their numbers in this assay, from the lowest: compounds 2, 3, 1 and 4 (each within the scatter of the next).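

Compound 4 adds a fourth ring on the amide-type nitrogen, and the picture in this assay stays flat: a 1.5-fold higher number from compound 2 to compound 4 (0.19 log units; within the scatter), a 1.2-fold higher number from compound 3 to compound 4 (0.09 log units; within the scatter) and a 1.1-fold higher number from compound 1 to compound 4 (0.05 log units; within the scatter). The earlier compounds had compared only the 2-fluorophenyl, 3-fluorophenyl and 2,4-dichlorophenyl rings, whereas these steps show that neither exchanging 3-fluorophenyl for 3,4-dichlorophenyl nor exchanging 2,4-dichlorophenyl for 3,4-dichlorophenyl moves the number beyond the scatter, and so among these four rings none can be ranked above another. No measurement at hand bears on why these rings give such similar numbers.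

On these data alone, all four rings are phenyl rings carrying only fluorine or chlorine, so it remains open whether a ring carrying an amine or a carboxylic acid, or a longer chain in place of the ring, would shift the number beyond the scatter. As far as these compounds go, it also remains open whether a change elsewhere on the shared core, such as on the phenyl ring of its other nitrogen, would separate these compounds.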